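The compounds below may be only part of what the source reports. "The series", "measured", "known", "first", "only" and "open" are said of these compounds alone.

Of the compounds shown here, three sharing one core have been measured in an ADME assay on MDBK cells (Bos taurus) for cytotoxicity, read by MTT assay, with a stated time of 96 h; on this read-out higher numbers stand for lower toxicity in this test and lower numbers for higher toxicity in this test. Compound 2 `Fc1ccc(-c2nc3cc(C(F)(F)F)ccc3[nH]2)cc1` gives 19000 nM, the highest of the three numbers. Compound 3 `CC(=O)Nc1ccc(-c2nc3cc(C(F)(F)F)ccc3n2C2CCCCC2)cc1` gives 17000 nM in this assay, a number within the scatter of that of compound 2, so the two cannot be set apart. Compound 1 `O=C(CN1CCCCC1)Nc1ccc(-c2nc3cc(C(F)(F)F)ccc3[nH]2)cc1` gives 6000 nM in this assay, and its gap from compound 2 lies beyond the scatter, so compound 1 is the more toxic of the two on this read-out.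

The account now turns to compound 4 `O=C(CN1CCCC1)Nc1ccc(-c2nc3cc(C(F)(F)F)ccc3[nH]2)cc1`, which has not yet been measured. It differs from compound 2 by (((pyrrolidin-1-yl)methyl)carbonyl)amino in place of fluoro on an aromatic carbon. The group that enters resembles the side chain carried by compound 1. Because compound 1 gives 6000 nM while compound 2 gives 19000 nM, a step toward a lower number is expected for compound 4, of a size beyond the scatter, estimated as a 2.7-fold lower number from compound 2 to compound 4 (0.43 log units; beyond the scatter). Compound 4 is therefore expected to give about 7000 nM, within a range from 3000 nM to 16000 nM.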

Compound 4, half-maximal cytotoxic concentration: 15000 nM
The estimate for compound 4 lay 2.1-fold (0.33 log units) below the measured number; measured number inside the range.
By their numbers in this assay, from the lowest: compound 1; then compounds 4, 3 and 2 (each within the scatter of the next).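

In this assay, putting (((pyrrolidin-1-yl)methyl)carbonyl)amino in place of fluoro on this aromatic carbon, para to a large group, gives a 1.3-fold lower number from compound 2 to compound 4 (0.10 log units; within the scatter) and so leaves the two compounds impossible to set apart, even though the entering group has far more heavy atoms than the fluoro it replaces. Carrying an amide side chain at this position therefore does not by itself go with a lower number, since the modest step of pyrrolidin-1-yl in place of piperidin-1-yl at the end of that chain gives a 2.5-fold higher number from compound 1 to compound 4 (0.40 log units; beyond the scatter) and shows that the ring at the end of the chain matters on this read-out. No measurement shown here accounts for this difference between the five-membered and the six-membered ring.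

On these data alone, it remains open whether a morpholine or an open-chain amine such as diethylamine at the end of the chain would fall with compound 1 or with compound 4. The compounds also leave open how a longer chain between the carbonyl and the ring, or a carboxylic acid in place of the ring, would read in this test.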